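Aryl swap on the piperazine series: notes toward compound 4

A few compounds are considered here, and "the series" means these few. Any claim that something is new, unique, unknown or untested is made for them only; others in the source may bear on it.

Of the compounds shown here, three have been measured in an assay on HEK293 cells for inhibition of Voltage-dependent T-type calcium channel subunit alpha-1G (Homo sapiens), read by fluorescence, tested at 10 uM; a higher number here means more inhibition at the concentration tested (going by the name of the read-out), a lower number less inhibition. Compound 1 `CCCc1nc(-c2ccccc2)c(CNCCCN2CCN(c3ccc(OC)cc3)CC2)o1` gives 42.1% in this assay. Compound 2 `CCCc1nc(-c2ccccc2)c(CNCCN2CCN(c3ccc(C)cc3)CC2)o1` gives 48.1% in this assay, and compound 3 `Cc1nc(-c2ccccc2)c(CNCCCN2CCN(c3ccc(Cl)cc3)CC2)o1` gives 38.1% in this assay. Compound 1 stands second highest of the three numbers; its nearest neighbour is compound 3, lower by a gap that lies within the scatter, and the furthest is compound 2, higher by a gap that also lies within the scatter. Among the measured compounds shown here, no ordering among the three can therefore be read from these numbers, and no step between two measured compounds differing in a single place is available.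

Compound 4 `CCCc1nc(-c2ccccc2)c(CNCCCN2CCN(c3cccc(C)c3C)CC2)o1` is to be measured in this assay. Relative to compound 1 the change is 2,3-dimethylphenyl in place of 4-methoxyphenyl on an amine nitrogen in a ring. The three measured compounds already carry three different aryl groups on that ring nitrogen and sit within the scatter of one another, so the step from compound 1 to compound 4 is expected to be small, a number 1.9 percentage points higher from compound 1 to compound 4 (within the scatter), in no particular direction beyond the scatter. Compound 4 is accordingly estimated at 44% in this assay, with a range from 30% to 58% expected.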

Compound 4, a percentage reported as inhibition, at one concentration (the size of the read-out at that concentration, not a potency): 55.2%
The estimate for compound 4 lay 11.2 percentage points below the measured number, within the range that was stated.
By their numbers in this assay, from the lowest: compounds 3, 1, 2 and 4 (each within the scatter of the next, the first and the last beyond it).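

In this assay, among the compounds shown here, the aryl group on the ring nitrogen now gives the first readable step: 2,3-dimethylphenyl in place of 4-methoxyphenyl gives a number 13.1 percentage points higher from compound 1 to compound 4 (beyond the scatter), a modest step but beyond the scatter, so this position is not silent in this assay. The two groups have the same heavy-atom count, a six-membered aromatic carbon ring and no net charge, so the step appears without any change in those counts, while the oxygen and its single hydrogen-bond acceptor leave and two methyl groups enter. Nothing measured here bears on the origin of the step, so it stands as an observation only.

For the compounds shown here, the single step does not separate the loss of the methoxy group from the arrival of the two methyl groups, and 2,3-dimethoxyphenyl, unsubstituted phenyl or a pyridine ring on the same ring nitrogen of the core of compound 1 would help to pull these apart. Going by these compounds, it also remains open whether the step carries over to the different linker of compound 2 or the different alkyl group of compound 3.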